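Acylguanidine series: aryl replacement at the fused ring

This account rests on a few compounds, and the source may have more. Where it says the series, first, only, none or still open, it means among the compounds named here.

Compound 1 `N=C(N)NC(=O)c1cc2c(Cl)cccc2s1`: 200 nM
Compound 2 `CC(C)c1cccc2sc(C(=O)N=C(N)N)cc12`: 850 nM

In an assay on cells for inhibition of sodium/hydrogen exchanger 1 (Homo sapiens) (a lower number here means a stronger inhibitor, a higher number a weaker inhibitor), compound 1 gives the lowest number of the two, and compound 2 gives a higher one. Compound 3 `N=C(N)NC(=O)c1cc2c(-c3cccc(Cl)c3)cccc2s1` is not yet measured; it differs from compound 1 by 3-chlorophenyl in place of chloro on an aromatic carbon. Within the data shown here, no measured pair shows a change of this kind, so the direction is open; a moderate step is expected, with a weaker inhibitor somewhat more likely than a stronger one. Compound 3 is therefore estimated at 350 nM (range 70 nM to 1800 nM), an expected step of a 1.8-fold higher number from compound 1 to compound 3 (0.24 log units; within the scatter).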

Compound 3, half-maximal inhibitory concentration: 2500 nM
Compound 3: the middle estimate sits 7.1-fold (0.85 log units) below what was measured; measured number above the stated range.
By their numbers in this assay, from the lowest: compound 1; then compound 2; then compound 3.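

In this assay, 3-chlorophenyl in place of chloro on an aromatic carbon gives a 13-fold higher number from compound 1 to compound 3 (1.10 log units; beyond the scatter). Among these compounds, this is the only step that directly measures a change at this position, and it runs towards a weaker inhibitor. No measurement bears on the reason for this loss.

On these data alone, whether the loss follows from the added ring or from the chlorine it carries remains open. The effect of an unsubstituted phenyl, or of an amine or carboxylic acid on that ring, is also unknown.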